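The compounds below may be only part of what the source reports. "The series", "measured", "known", "first", "only" and "open" are said of these compounds alone.

The study sets four compounds side by side on two different cores. Compound 1 `O=c1cc(CSC(=S)N2CCCC2)oc2cc(Cl)ccc12` and compound 2 `CC(C)N(C(=S)SCc1cc(=O)c2ccc(Cl)cc2o1)C(C)C` share the core of compound 1 and differ only by diisopropylamino in place of pyrrolidin-1-yl on a thiocarbonyl carbon. In a functional assay on SW480 cells (Homo sapiens) for antiproliferative activity, read by MTT assay, with a stated time of 72 h (a lower number here means a stronger inhibitor, a higher number a weaker inhibitor), compound 1 gives no number but a limit of the assay, > 25000 nM. Compound 2 likewise returns only a limit of the assay in this assay, > 25000 nM. The step that the two limits leave unreadable from compound 1 to compound 2 is therefore of unreadable size, because both values sit at the limit of > 25000 nM in this assay, at which 2 of the 3 values shown sit.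

Compound 3 `Cc1ccc2c(=O)c(CSC(=S)N3CCCC3)coc2c1` stands on a second core; how the two cores differ is not broken down here. In this assay compound 3 gives 5900 nM. Among the three measured compounds it is the only one with a plain number; the other two return limits of the assay.

Compound 4 `Cc1ccc2c(=O)c(CSC(=S)N(C(C)C)C(C)C)coc2c1` has not yet been measured. It differs from compound 3 by diisopropylamino in place of pyrrolidin-1-yl on a thiocarbonyl carbon, and since the place is described in the same words as for the pair of compound 1 and compound 2, this is the same change, seen twice among the compounds shown. Its one measured occurrence gives no readable size, so the expectation for compound 4 rests mainly on the value of compound 3, 5900 nM, with wide room on either side. Compound 4 is expected to give about 8000 nM in this assay, with a likely range from 2500 nM to 25000 nM. The step this estimate implies is expected to be a 1.4-fold higher number from compound 3 to compound 4 (0.13 log units; within the scatter).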

Compound 4, half-maximal inhibitory concentration: > 25000 nM
Compound 4: a limit, no number; the forecaster's own chance of this, stated with the estimate: 30%; middle value at least 3.1-fold (0.49 log units) from the limit.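

In this assay, on these data alone, putting diisopropylamino in place of pyrrolidin-1-yl on the thiocarbonyl carbon of the second core gives an at least 4.2-fold higher number from compound 3 to compound 4 (0.62 log units; beyond the scatter); this is a clear loss of activity, but its full size stays unknown, as compound 4 returns a limit of the assay and not a number. On the core of compound 1 the same change cannot be read, because compound 1 and compound 2 both return only a limit, and compound 4 joins them there: the limit of > 25000 nM in this assay, at which 3 of the 4 values shown sit. The series therefore shows the change as a loss on one core only, and it does not show that the loss carries over from one core to the other, although nothing shown speaks against that either.

The compounds shown leave open how much activity compound 4 has, if any, and whether any amine other than these two on the thiocarbonyl carbon would keep a plain number on the core of compound 3, which gives 5900 nM. A pair with dimethylamino and piperidin-1-yl in that place would help to tell whether the ring or the size of the amine goes with the difference.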